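The compounds below may be only part of what the source reports. "The series", "measured", "known", "first", "only" and "open" are said of these compounds alone.

Measured in a functional assay on the whole organism (aorta) with Rattus norvegicus as the target; a higher number here means a larger maximal response, a lower number a smaller maximal response:

Compound 1, `CNC(=O)C1=CC(C)(C(F)(F)F)Oc2ccc([N+](=O)[O-])cc21`: 61.7%
Compound 2, `CNC(=O)C1=CC(C(F)(F)F)(C(F)(F)F)Oc2ccc([N+](=O)[O-])cc21`: 57.9%

Compound 2 and compound 1 lie within the scatter of each other, so neither can be called larger or smaller in its response. Within the data shown here, the single measured step, a number 3.8 percentage points lower from compound 1 to compound 2 (within the scatter), exchanges a methyl for a trifluoromethyl on a saturated ring carbon and stays within the scatter.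

Compound 3, `N#CCC/N=C(/S)C1=CC(C(F)(F)F)(C(F)(F)F)Oc2ccc([N+](=O)[O-])cc21`, has not yet been measured in this assay. It differs from compound 2 as follows: a group of 7 heavy atoms (4 carbon, 2 nitrogen, 1 sulfur; no ring) in place of a group of 4 heavy atoms (2 carbon, 1 nitrogen, 1 oxygen; no ring), on a double-bonded ring carbon. The methylcarbamoyl leaves and a group with a sulfur and a nitrile enters, on a double-bonded ring carbon of the shared core.

Among the measured compounds shown here, the one measured step concerns a different place and a smaller exchange, so it bears only loosely on this change; no step beyond the scatter can be argued from it, but the uncertainty is wide. The expected step is a number 2.9 percentage points lower from compound 2 to compound 3 (within the scatter), within the scatter. For compound 3 the estimated response is 55%, with a range from 25% to 85%.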

Compound 3, intrinsic activity: the largest response reached, in percent of the reference agonist's: 74.8%
Estimate against measurement, compound 3: 19.8 percentage points below; the measured number falls inside the stated range.
By their numbers in this assay, from the lowest: compounds 2 and 1 (each within the scatter of the next); then compound 3.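

In this assay, replacing the methylcarbamoyl on the double-bonded ring carbon with the group carrying a sulfur and a nitrile gives a number 16.9 percentage points higher from compound 2 to compound 3 (beyond the scatter), the only step shown that lies beyond the scatter. This shows that the maximal response can be moved by a change at this position, which the earlier pair could not show: its exchange of methyl for trifluoromethyl, on a different ring carbon, gave a number 3.8 percentage points lower from compound 1 to compound 2 (within the scatter). The two exchanges differ in size as well as in place, so this does not rank one position above the other, and no measurement here explains the rise.

The sulfur, the nitrile and the longer chain all enter together in this one exchange, so it remains open which of them, if any single one, accounts for the step. Also open, on these data alone, are how an amine, a carboxylic acid or a plain propyl chain in place of the nitrile-bearing chain would behave here, and whether the same exchange would give a similar step on the core of compound 1.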